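The source may report more compounds than this note shows. Statements on the series, on what has been measured and on what is new or still open speak of the compounds shown alone.

So far two compounds with a shared core have been measured in a functional assay on SGC-7901 cells (Homo sapiens) for inhibition, read by MTT assay, with a stated time of 24 h (a higher number here means a weaker inhibitor, a lower number a stronger inhibitor), and both have numbers. Compound 1 (`CC1(C)[C@H]2CC[C@]1(C)N(Cc1cn(-c3ccccc3Cl)nn1)C(=O)C2`) gives 220 nM and compound 2 (`CC1(C)[C@H]2CC[C@]1(C)N(Cc1cn(-c3ccc(Br)cc3)nn1)C(=O)C2`) gives 450 nM as the higher of the two numbers, which makes compound 2 the weaker inhibitor of this pair. Compound 3 (`CC1(C)[C@H]2CC[C@]1(C)N(Cc1cn(-c3cccc(O)c3)nn1)C(=O)C2`) keeps the core of compound 2 and differs only on an aromatic nitrogen of a five-membered aromatic ring, where 3-hydroxyphenyl stands in place of 4-bromophenyl (3-hydroxyphenyl in place of 4-bromophenyl on an aromatic nitrogen). Within the data shown here, one measured step bears on this change, and it is a 2.0-fold higher number from compound 1 to compound 2 (0.31 log units; beyond the scatter) for a swap on that same aromatic nitrogen, with 4-bromophenyl in place of 2-chlorophenyl. Among the measured compounds shown here, that step is modest, but it is a single one, and no measured compound carries 3-hydroxyphenyl, so the direction of the new change remains open. The estimated step is a 1.4-fold lower number from compound 2 to compound 3 (0.15 log units; within the scatter) and it is not expected to lie beyond the scatter. For compound 3 the expected value is 320 nM (estimated range 110 nM to 950 nM).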

Compound 3, half-maximal inhibitory concentration: 270 nM
Estimate against measurement, compound 3: 1.2-fold (0.07 log units) above; the measured number falls inside the stated range.
By their numbers in this assay, from the lowest: compounds 1, 3 and 2 (each within the scatter of the next, the first and the last beyond it).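

In this assay the aromatic nitrogen of the five-membered ring carries 3-hydroxyphenyl as readily as the two halogen-bearing phenyl groups, so a ring with a hydrogen-bond donor and acceptor can replace one with neither without a change that stands out from the noise: the swap from 4-bromophenyl gives a 1.7-fold lower number from compound 2 to compound 3 (0.22 log units; within the scatter) and the swap from 2-chlorophenyl gives a 1.2-fold higher number from compound 1 to compound 3 (0.09 log units; within the scatter). Compound 3 therefore sits within the scatter of both earlier compounds, even though those two lie beyond the scatter of each other, and the gap that looked like a first trend at this position is now bridged by a group of a different kind. No measurement here explains why these three groups give such similar numbers.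

Each of the three phenyl groups differs from the others in both its substituent and where that substituent sits, so the effect of the substituent cannot be separated from the effect of its place on the ring. Also open, going by these compounds, is how this assay would read an amine or a carboxylic acid on that phenyl ring, or a longer chain in place of the ring.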